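From Fluoro to Trifluoromethyl on a Shared Core

The compounds below may be only part of what the source reports. "The series", "measured", "known", "first", "only" and "open" are said of these compounds alone.

Of the compounds shown here, two built on one shared core have been measured in a functional assay on HepG2 cells (Homo sapiens) for cytotoxicity, read by MTT assay, with a stated time of 2 days; a lower number here means a stronger inhibitor, a higher number a weaker inhibitor. Compound 1 `c1ccc(CO/N=C2/C(c3c[nH]c4ccccc34)=Nc3ccccc32)cc1` gives 19500 nM in this assay. Compound 2 `Fc1ccc(CO/N=C2/C(c3c[nH]c4ccccc34)=Nc3ccccc32)cc1` gives 35500 nM in this assay. For the measured compounds named here, the one measured step between them, a 1.8-fold higher number from compound 1 to compound 2 (0.26 log units; within the scatter), is the only comparison available. Going by the values given here, compound 2 stands at the higher of the two numbers, with compound 1 as its sole neighbour, and since the two lie within the scatter of each other no order can be read between them.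

Compound 3 `FC(F)(F)c1ccc(CO/N=C2/C(c3c[nH]c4ccccc34)=Nc3ccccc32)cc1` has not yet been measured. It differs from compound 2 by trifluoromethyl in place of fluoro on an aromatic carbon. Among the compounds with values here, no measured step carries this same change. Within the data shown here, the only step known, fluoro in place of hydrogen on an aromatic carbon from compound 1 to compound 2, stayed within the scatter, and the data give no further guide. On that footing the expected step is a 1.0-fold lower number from compound 2 to compound 3 (0.01 log units; within the scatter), with no movement beyond the scatter anticipated. Compound 3 is therefore estimated at 35000 nM in this assay, with a range from 12000 nM to 100000 nM.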

Compound 3, half-maximal inhibitory concentration: 22300 nM
Compound 3: the middle estimate sits 1.6-fold (0.20 log units) above what was measured; measured number inside the range.
By their numbers in this assay, from the lowest: compounds 1, 3 and 2 (each within the scatter of the next).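

In this assay this place, on an aromatic carbon of a six-membered aromatic ring of carbon only and para to a large group, has now been read with three different occupants, and the larger trifluoromethyl adds a test that fluoro alone could not give. Trifluoromethyl in place of fluoro gives a 1.6-fold lower number from compound 2 to compound 3 (0.20 log units; within the scatter) while trifluoromethyl in place of hydrogen gives a 1.1-fold higher number from compound 1 to compound 3 (0.06 log units; within the scatter) so neither hydrogen, fluoro nor trifluoromethyl can be told apart here, and going from 4-fluorophenyl to 4-(trifluoromethyl)phenyl leaves the reading of this position as flat as it was after the single earlier step. Nothing measured on these compounds offers an explanation for this flat reading.

On these data alone, whether any occupant of this place can move the number beyond the scatter stays open, since an amine, a carboxylic acid, a methoxy group or a longer chain would each put something quite different there than the fluorine-bearing groups and hydrogen seen so far. As far as these compounds go, all three compounds also keep the rest of the shared core unchanged, so what a change elsewhere on it would do remains unknown.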